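Purine nucleoside series: bromo to methylsulfanyl on the core

This account rests on a few compounds, and the source may have more. Where it says the series, first, only, none or still open, it means among the compounds named here.

Compound 1, `CSc1nc(SC)c2ncn([C@@H]3C[C@@H](O)[C@H](CO)O3)c2n1`, carries two methylsulfanyl groups on the shared core. In a functional assay on U-937 cells (Homo sapiens) (a higher number here means a weaker inhibitor, a lower number a stronger inhibitor), compound 1 gives a limit, > 300 uM, and no number. Compound 2, `CN(C)c1nc(Br)nc2c1ncn2[C@@H]1C[C@@H](O)[C@H](CO)O1`, pairs a dimethylamino group with a bromo group on the same core. In this assay, within the data shown here, compound 2 gives 164 uM, the only number so far; the other value shown is the limit of > 300 uM in this assay, at which 1 of the 2 values shown sits. Among the measured compounds shown here, no step between two measured compounds is available. Compound 3, `CSc1nc(N(C)C)c2ncn([C@@H]3C[C@@H](O)[C@H](CO)O3)c2n1`, differs from compound 2 by methylsulfanyl in place of bromo on an aromatic carbon. Compound 3 thus shares the dimethylamino group of compound 2 and one methylsulfanyl group of compound 1. The step from compound 2 to compound 3 is expected to be small and toward weaker inhibition, about a 1.4-fold higher number from compound 2 to compound 3 (0.15 log units; within the scatter). The reason is the limit of > 300 uM in this assay, at which 1 of the 2 values shown sits, the value of compound 1 in this assay, > 300 uM. Compound 3 is therefore estimated at 230 uM, with a range from 90 uM to 500 uM, and a fair chance that only a limit is reported.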

Compound 3, concentration for 50% inhibition: 126 uM
Compound 3: middle estimate off by 1.8-fold (0.26 log units), on the high side; low and high end bracket the measured number.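

In this assay, methylsulfanyl in place of bromo on the aromatic carbon between two ring nitrogen atoms gives a 1.3-fold lower number from compound 2 to compound 3 (0.11 log units; within the scatter), so with the dimethylamino group present, this position takes either group without a readable change. Among these compounds, the first step beyond the scatter comes from the other substituted carbon, with dimethylamino in place of methylsulfanyl: an at least 2.3-fold lower number from compound 1 to compound 3 (0.37 log units; beyond the scatter). The size of that step is only a bound, since the value of compound 1 is a limit: the limit of > 300 uM in this assay, at which 1 of the 3 values shown sits.

Whether bromo and methylsulfanyl would also match each other without the dimethylamino group cannot be read from these compounds. Also open, from the compounds shown here alone, is how a primary amine, a carboxylic acid or a longer chain such as ethylsulfanyl would read at the position between two ring nitrogen atoms.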